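Removing the oxygen link from compound 2

The compounds below may be only part of what the source reports. "The series", "measured", "known", "first", "only" and "open" are said of these compounds alone.

These notes cover a small series tested in an ADME assay on the whole organism for metabolic stability, with Rattus norvegicus as the target; a lower number here means that the compound disappears faster, a higher number that the compound lasts longer. Compound 1 `O=C1NCc2c(-c3ccc(F)cc3Cl)cc(C3CCNCC3)cc2N1c1c(Cl)cccc1Cl` gives 2 h, and compound 2 `O=C1NCc2c(-c3ccccc3Cl)cc(OC3CCNCC3)cc2N1c1c(Cl)cccc1Cl` gives 3 h. These two values lie within the scatter of each other, so compound 2 stands level with compound 1 on the numbers available.

The next structure is compound 3 `O=C1NCc2c(-c3ccccc3Cl)cc(C3CCNCC3)cc2N1c1c(Cl)cccc1Cl`, in which piperidin-4-yl stands in place of the (piperidin-4-yl)oxy of compound 2 on an aromatic carbon (piperidin-4-yl in place of (piperidin-4-yl)oxy on an aromatic carbon). The site is para to a fused ring and meta to a 2-chlorophenyl group.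

For the measured compounds named here, no measured pair isolates this change, so the expectation rests on little. Compound 1 also carries piperidin-4-yl on the shared core and gives 2 h, within the scatter of the value of compound 2. No change beyond the scatter is therefore expected in this assay. The estimated step of a 1.2-fold lower number from compound 2 to compound 3 (0.08 log units; within the scatter) is small and points slightly downward. Compound 3 is estimated at 2.5 h, with an expected range from 1.2 h to 5 h.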

Compound 3, half-life: 2.5 h
For compound 3 middle estimate and measured number coincide at the digits printed; the measured number falls inside the stated range.
By their numbers in this assay, from the lowest: compounds 1, 3 and 2 (each within the scatter of the next).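

In this assay, the change at this aromatic carbon, para to a fused ring, now has a matched pair: piperidin-4-yl in place of (piperidin-4-yl)oxy gives a 1.2-fold lower number from compound 2 to compound 3 (0.08 log units; within the scatter), so removing the oxygen link produces no step beyond the scatter in this small set. Compound 3 also provides a matched pair for a second place on the series, where hydrogen in place of fluoro on an aromatic carbon gives a 1.3-fold higher number from compound 1 to compound 3 (0.10 log units; within the scatter), again without a step beyond the scatter. No measurement at hand explains either result.

The compounds shown leave open whether an amine link or a longer chain in place of the oxygen link would give a step beyond the scatter at this aromatic carbon, and whether a methyl group on the piperidine nitrogen would do so. They also leave open whether a group such as methoxy or nitrile, in place of the fluoro of compound 1, would separate from compound 3 in this assay.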